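Lengthening the hydroxyalkyl chain on a pituitary-cell series

The source may report more compounds than this note shows. Statements on the series, on what has been measured and on what is new or still open speak of the compounds shown alone.

The measured compounds and their values in a functional assay (Pituitary gland cell) with Rattus norvegicus as the target; on this read-out higher numbers stand for an effect only at larger amounts of compound and lower numbers for an effect already at smaller amounts:
Compound 1 `COc1ccc(CNC(=O)c2ccccc2-c2ccc(CN3C(=O)[C@H](NC(=O)CC(C)(C)N)CCc4ccccc43)cc2)cc1` gives 2 uM.
Compound 2 `CC(C)(N)CC(=O)N[C@@H]1CCc2ccccc2N(Cc2ccc(-c3ccccc3C(=O)NCc3ccc(O)cc3)cc2)C1=O` gives 0.3 uM.
Compound 3 `CC(C)(N)CC(=O)N[C@@H]1CCc2ccccc2N(Cc2ccc(-c3ccccc3C(=O)NCCCO)cc2)C1=O` gives 0.4 uM.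

Compound 3 stands second highest of the three numbers in this assay. It sits close to compound 2, the gap being a 1.3-fold higher number from compound 2 to compound 3 (0.12 log units; within the scatter), while compound 1 lies clearly apart, as the step of a 5.0-fold lower number from compound 1 to compound 3 (0.70 log units; beyond the scatter) shows. The third measured pair, a 6.7-fold lower number from compound 1 to compound 2 (0.82 log units; beyond the scatter), also concerns the group on the amide nitrogen at the end of the shared core, and together these steps say that replacing the 4-methoxyphenyl group there lowers the number, whether the new group is 4-hydroxyphenyl or 2-hydroxyethyl.

Compound 4 `CC(C)(N)CC(=O)N[C@@H]1CCc2ccccc2N(Cc2ccc(-c3ccccc3C(=O)NCCCCO)cc2)C1=O` differs from compound 3 by hydroxymethyl in place of hydroxy on a saturated chain carbon, three bonds along the chain from an amide-type nitrogen. Among the measured compounds shown here, no measured pair shows a chain lengthened by one carbon in this way, so the expectation rests on the observation that two quite different hydroxy-bearing groups at this position, in compound 2 and compound 3, give numbers within the scatter of each other. The expected step is therefore no change at the digits printed from compound 3 to compound 4 (within the scatter), that is, none beyond the scatter. Compound 4 is estimated to give 0.4 uM in this assay, with a likely range from 0.15 uM to 1 uM.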

Compound 4, concentration for half-maximal effect: 0.01 uM
The estimate for compound 4 lay 40-fold (1.60 log units) above the measured number; measured number below the stated range.
By their numbers in this assay, from the lowest: compound 4; then compounds 2 and 3 (each within the scatter of the next); then compound 1.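

In this assay, the change from 3-hydroxypropyl to 4-hydroxybutyl adds a single carbon and gives a 40-fold lower number from compound 3 to compound 4 (1.60 log units; beyond the scatter) at a position where compound 2 and compound 3 had looked alike, so two very different groups can match here while one added carbon on the chain has a large effect. The 4-hydroxybutyl chain also stands well clear of the ring-bearing groups, as shown by a 30-fold lower number from compound 2 to compound 4 (1.48 log units; beyond the scatter) and by a 200-fold lower number from compound 1 to compound 4 (2.30 log units; beyond the scatter) in the same assay, which makes chain length the sharpest difference seen at this position so far. Nothing available here accounts for the size of this drop.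

The compounds shown leave open whether a longer chain, such as 5-hydroxypentyl, would lower the number further or whether the trend ends at 4-hydroxybutyl. They also leave open how much depends on the hydroxy group itself, a question that a plain butyl chain, or an amine or a carboxylic acid at the chain end, could help to answer.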